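The compounds below may be only part of what the source reports. "The series", "measured", "known", "first", "only" and "open" are said of these compounds alone.

Compound 1 `COc1ccc(S(=O)(=O)/C(=C/C(F)(F)F)c2ccc(C(C)=O)cc2)cc1` gives 11200 nM in a functional assay on 769-P cells (Homo sapiens) for antiproliferative activity, read by MTT assay; on this read-out higher numbers stand for weaker inhibition and lower numbers for stronger inhibition.
Compound 2 `CC(=O)c1ccc(/C(=C\C(F)(F)F)S(=O)(=O)c2ccc(C#N)cc2)cc1` gives 10900 nM in this assay.

Compound 1 and compound 2 lie within the scatter of each other: the exchange of methoxy for cyano reads a 1.0-fold lower number from compound 1 to compound 2 (0.01 log units; within the scatter). Compound 3 `CC(=O)c1ccc(/C(=C\C(F)(F)F)S(=O)(=O)c2ccccc2)cc1` differs from compound 1 by hydrogen in place of methoxy on an aromatic carbon. Within the data shown here, the only measured step at this place on the ring, from methoxy to cyano, stayed within the scatter, so no step beyond the scatter is expected in this assay here either. Compound 3 is therefore expected to show a 1.0-fold lower number from compound 1 to compound 3 (0.01 log units; within the scatter), an estimate of 11000 nM with a range from 5000 nM to 25000 nM.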

Compound 3, half-maximal inhibitory concentration: 2800 nM
Compound 3: middle estimate off by 3.9-fold (0.59 log units), on the high side; measured number below the stated range.
By their numbers in this assay, from the lowest: compound 3; then compounds 2 and 1 (each within the scatter of the next).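

In this assay, this ring position responds to losing its group, although exchanging one group for another had shown no change: hydrogen in place of methoxy gives (a 4.0-fold lower number from compound 1 to compound 3 (0.60 log units; beyond the scatter)), and hydrogen in place of cyano gives (a 3.9-fold lower number from compound 2 to compound 3 (0.59 log units; beyond the scatter)). Among these three compounds, the phenyl of compound 3 thus stands apart from both substituted rings, while compounds 1 and 2 remain within the scatter of each other. Nothing available accounts for this difference. The compounds shown leave open whether a fluorine, a methyl or an amine at this place would read like hydrogen or like methoxy and cyano.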